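Cyclopentyl amide on the indole-carboxamide series

The source may report more compounds than this note shows. Statements on the series, on what has been measured and on what is new or still open speak of the compounds shown alone.

Compound 1 `CCC1C(=O)N(C)c2cnc(-n3ccc4cc(C(N)=O)ccc43)nc2N1c1ccn(C)n1` is reported in a functional assay on MCF7 cells (Homo sapiens) for antiproliferative activity, read by CCK-8 assay, with a stated time of 72 h (a lower number here means a stronger inhibitor of growth, a higher number a weaker inhibitor of growth), as "not active" (no number reported), with no number given, so it stands at the inactive end of the series. Compound 2 `CC[C@@H]1C(=O)N(C)c2cnc(-n3ccc4cc(C(=O)NCC(C)C)ccc43)nc2N1C1CCCC1` gives 953 nM in this assay, and compound 3 `CCC1C(=O)N(C)c2cnc(Nc3ccc(S(N)(=O)=O)cc3)nc2N1c1ccn(C)n1` gives 36600 nM. The change from compound 1 to compound 4 `CCC1C(=O)N(C)c2cnc(-n3ccc4cc(C(=O)NC5CCCC5)ccc43)nc2N1c1ccn(C)n1` is cyclopentyl in place of hydrogen on an amide-type nitrogen. Among the compounds with values here, no measured pair shows this exact step, so the expected size rests on compound 2, whose carboxamide carries a substituted nitrogen and which reads at 953 nM; a move in the direction of stronger growth inhibition, beyond the scatter, is expected. Compound 4 is therefore estimated at 3000 nM in this assay, within a range from 500 nM to 30000 nM.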

Compound 4, concentration for 50% growth inhibition: "not active" (no number reported)
For compound 4 the study gives words and no number; no gap can be computed for the estimate.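

Compound 1 and compound 4 are both reported in this assay in words without a number, so no step can be read between them. No supporting evidence bears on this result. Going by these compounds, whether cyclopentyl in place of hydrogen on the amide-type nitrogen changes growth inhibition remains open.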